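The source may report more compounds than this note shows. Statements on the series, on what has been measured and on what is new or still open speak of the compounds shown alone.

The series rests on a shared core that carries a carboxylic acid on one aromatic ring and an imidazole linked to the other, and it was examined in an in vitro functional assay on cells for agonist activity at Bombesin receptor subtype-3 (Homo sapiens), read by luminescence and calcium flux; a higher number here means that more compound is needed for the effect, a lower number that less compound is needed. Among the measured compounds shown here, compound 1, `CCCCc1cnc(Cc2ccc(-c3ccccc3C(=O)O)cc2)[nH]1`, is the first member. In this assay compound 1 reaches only the limit of > 10000 nM, which is a limit of the assay rather than a number, as shown by the limit of > 10000 nM in this assay, at which 1 of the 2 values shown sits. For the measured compounds named here, compound 2, `O=C(O)c1ccccc1-c1ccc(CCc2ncc(Cc3ccc(Cl)cc3)[nH]2)cc1`, gives 2290 nM in this assay, and that is the only actual number so far. The next member, compound 3, `O=C(O)c1ccccc1-c1ccc(CCc2ncc(Cc3cccc(F)c3F)[nH]2)cc1`, has not yet been tested in this assay. It differs from compound 2 in one place only, (2,3-difluorophenyl in place of 4-chlorophenyl on a saturated chain carbon bound to an aromatic carbon). Going by the values given here, no measured step of that kind stands beside it, so the expectation rests on compound 2 alone. The step from compound 2 to compound 3 is expected to be a 1.5-fold higher number from compound 2 to compound 3 (0.18 log units; within the scatter), a modest shift towards needing more compound, within or just beyond the scatter. Compound 3 is therefore estimated at 3500 nM in this assay, with a likely span from 1200 nM to 10000 nM.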

Compound 3, half-maximal effective concentration: 87 nM
Beside the measured number, compound 3's estimate is 40-fold (1.60 log units) above it; the measured number lies below the stated range.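

Among the compounds shown here, the position on a saturated chain carbon bound to an aromatic carbon had no measured step until now, and it proves highly responsive in this assay: 2,3-difluorophenyl in place of 4-chlorophenyl gives a 26-fold lower number from compound 2 to compound 3 (1.42 log units; beyond the scatter), so much less compound is needed for the effect. The change is confined to the halogens on the ring, since both groups are one six-membered aromatic ring of carbon only, with no hydrogen-bond donors, no hydrogen-bond acceptors and no net charge. Nothing shown gives a measured property that would account for a step of this size.

For the compounds shown here, with only this one pair, it remains open whether the step comes from the loss of the chlorine or the entry of the fluorines, and an unsubstituted phenyl or a phenyl carrying a single fluorine at this place would help to separate the two. Going by these compounds, it is also open whether the 2,3-difluorophenyl group would keep this effect if a tetrazole took the place of the carboxylic acid on the shared core.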